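The source may report more compounds than this note shows. Statements on the series, on what has been measured and on what is new or still open speak of the compounds shown alone.

Measured in a functional assay on SW 1116 cells (Homo sapiens) for antiproliferative activity, read by MTT assay, with a stated time of 24 h; on this read-out higher numbers stand for weaker inhibition and lower numbers for stronger inhibition:
Compound 1 `O=[N+]([O-])c1ccc(CSc2nnc(-c3ccc4c(c3)OCCO4)n2-c2ccccc2)cc1`: 13800 nM
Compound 2 `Cc1ccccc1CSc1nnc(-c2ccc3c(c2)OCCO3)n1-c1ccccc1`: 12700 nM
Compound 3 `Fc1cccc(F)c1CSc1nnc(-c2ccc3c(c2)OCCO3)n1-c1ccccc1`: 9010 nM

Compound 3, at 9010 nM, cannot be told apart from the other two compounds, as all three values lie within the scatter of one another. Compound 4 `Brc1cccc(CSc2nnc(-c3ccc4c(c3)OCCO4)n2-c2ccccc2)c1` keeps the shared core and differs from compound 3 only in the group on a saturated chain carbon bound to a sulfur: 3-bromophenyl in place of 2,6-difluorophenyl on a saturated chain carbon bound to a sulfur.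

The measured steps that bear on this change are those that exchange the group at this same place. They are a 1.1-fold lower number from compound 1 to compound 2 (0.04 log units; within the scatter), a 1.5-fold lower number from compound 1 to compound 3 (0.19 log units; within the scatter) and a 1.4-fold lower number from compound 2 to compound 3 (0.15 log units; within the scatter). None of them goes beyond the scatter, even though 4-nitrophenyl, 2-methylphenyl and 2,6-difluorophenyl are all represented. Within the data shown here, no measured compound carries 3-bromophenyl, so this expectation is an extrapolation and the range is kept wider than those steps alone would suggest. No step beyond the scatter is expected in this assay, and no direction can be favoured. The expected result is a 1.1-fold higher number from compound 3 to compound 4 (0.05 log units; within the scatter). Compound 4 is estimated at 10000 nM, with an expected range of 4500 nM to 22000 nM.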

Compound 4, half-maximal inhibitory concentration: 26200 nM
Compound 4: middle estimate off by 2.6-fold (0.42 log units), on the low side; measured number above the stated range.
By their numbers in this assay, from the lowest: compounds 3, 2, 1 and 4 (each within the scatter of the next, the first and the last beyond it).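

In this assay, no earlier exchange at this position had gone beyond the scatter, but 3-bromophenyl on a saturated chain carbon bound to a sulfur gives a 2.9-fold higher number from compound 3 to compound 4 (0.46 log units; beyond the scatter) and a 2.1-fold higher number from compound 2 to compound 4 (0.31 log units; beyond the scatter), so the group at this place can move the number, here modestly and towards weaker inhibition. The shift does not set compound 4 apart from every other compound, since the exchange for 4-nitrophenyl gives a 1.9-fold higher number from compound 1 to compound 4 (0.28 log units; within the scatter) and compound 1 therefore goes against any claim that 3-bromophenyl differs from all the other groups. Nothing in the data shown explains why this exchange behaves differently from the earlier ones.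

All four compounds shown carry a substituted phenyl at this place on the same shared core, so they leave open how an unsubstituted phenyl, a pyridine ring or a plain butyl chain would read in this assay. They also leave open whether the exchange of 2,6-difluorophenyl for 3-bromophenyl would give a step of similar size on a core carrying something other than the phenyl group that all four compounds share.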